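This account rests on a few compounds, and the source may have more. Where it says the series, first, only, none or still open, it means among the compounds named here.

Measured in a functional assay on the whole organism with Mus musculus as the target, with a stated time of 30 min; on this read-out higher numbers stand for an effect only at larger amounts of compound and lower numbers for an effect already at smaller amounts:
compound 1 `CC(=O)N1CCN(S(=O)(=O)c2ccc(F)cc2)CC1` gives 0.01 mg/kg
compound 2 `CCC(=O)N1CCCC(NC(=O)c2ccccc2)C1` gives 1 mg/kg
compound 3 `CC(=O)N1CCN(S(=O)(=O)c2ccc(F)cc2)CC1=O` gives 0.3 mg/kg

Compound 3 stands second highest of the three numbers in this assay. Its nearest neighbour is compound 2, whose value 1 mg/kg is higher, beyond the scatter; the furthest is compound 1, whose value 0.01 mg/kg is lower, also beyond the scatter. Within the data shown here, no two of the measured compounds differ in a single place, so no single step is known to guide the next change.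

Compound 4 `CCC(=O)N1CCN(S(=O)(=O)c2ccc(F)cc2)CC1=O` is not yet measured in this assay. It differs from compound 3 by methyl in place of hydrogen on a saturated chain carbon bound to a carbonyl carbon. Compound 2 carries the same propanoyl group, but on another core, so its value 1 mg/kg says little about compound 4 directly. Among the measured compounds shown here, with no step of this kind known on the shared core of compound 3, a small change is expected, with no direction beyond the scatter: the step from compound 3 to compound 4 is estimated at no change at the digits printed from compound 3 to compound 4 (within the scatter). Compound 4 is therefore expected to give about 0.3 mg/kg, within a range from 0.1 mg/kg to 1 mg/kg.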

Compound 4, minimum effective dose: 0.3 mg/kg
Compound 4: middle estimate and measured number agree at the digits printed, within the range that was stated.
By their numbers in this assay, from the lowest: compound 1; then compounds 3 and 4 (each within the scatter of the next); then compound 2.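

The series now has its first step that differs in one place: on the shared core, acetyl to propanoyl in this assay gives no change at the digits printed from compound 3 to compound 4 (within the scatter) for methyl in place of hydrogen on a saturated chain carbon bound to a carbonyl carbon. The earlier compounds shown here gave no reading at this position, and this step shows that the position accepts one added methyl with no difference in minimum effective dose beyond the scatter. No measurement at hand accounts for this result, so it stands as an observation of this single pair.

One added carbon says little about how far the position stays this flat: a longer chain such as butanoyl, a branched chain, or a chain ending in an amine or a carboxylic acid could read differently from the propanoyl group of compound 4. As far as these compounds go, it also remains open whether the same step from acetyl to propanoyl would read the same on the core of compound 1, whose value is far from those of compound 3 and compound 4, though that gap is not a step in one place.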